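The compounds below may be only part of what the source reports. "The series", "measured", "known", "first", "only" and "open" are said of these compounds alone.

Compounds measured in an assay on CHO cells for antagonist activity at transient receptor potential cation channel subfamily V member 1 (Homo sapiens), read by FLIPR; on this read-out higher numbers stand for weaker inhibition and lower numbers for stronger inhibition:
Compound 1 `CCC1CCN(c2cc(C(F)(F)F)ccc2CNC(=O)C(C)c2ccc(NS(C)(=O)=O)c(F)c2)CC1` gives 0.7 nM.
Compound 2 `CC(C(=O)NCc1ccc(C(F)(F)F)cc1N1CCN(C2CCCCC2)CC1)c1ccc(NS(C)(=O)=O)c(F)c1` gives 13.8 nM.
Compound 3 `CC(C)COc1cc(C(F)(F)F)ccc1CNC(=O)C(C)c1ccc(NS(C)(=O)=O)c(F)c1` gives 0.8 nM.

Compound 3 stands second highest of the three numbers in this assay; its nearest neighbour is compound 1, with a 1.1-fold higher number from compound 1 to compound 3 (0.06 log units; within the scatter), and its furthest is compound 2, with a 17-fold lower number from compound 2 to compound 3 (1.24 log units; beyond the scatter). Compound 4 `CC(C(=O)NCc1ccc(C(F)(F)F)cc1OC1CCCCC1)c1ccc(NS(C)(=O)=O)c(F)c1` has not yet been measured. It differs from compound 3 by cyclohexyl in place of isobutyl on an oxygen on an aromatic ring. Going by the values given here, no measured step alters the alkyl on that oxygen, so the bearing steps are indirect: a 1.1-fold higher number from compound 1 to compound 3 (0.06 log units; within the scatter) shows that exchanging the 4-ethylpiperidin-1-yl for isobutoxy at the same aromatic carbon changed little, whereas a 20-fold higher number from compound 1 to compound 2 (1.29 log units; beyond the scatter) shows that the larger 4-cyclohexylpiperazin-1-yl cost a great deal. A cyclohexyl in place of isobutyl is a modest enlargement, so compound 4 is expected to give a step of a 1.9-fold higher number from compound 3 to compound 4 (0.27 log units; within the scatter) in this assay, likely within the scatter or slightly higher. The estimate for compound 4 is 1.5 nM, with a range from 0.4 nM to 6 nM.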

Compound 4, inhibition constant: 0.7 nM
Beside the measured number, compound 4's estimate is 2.1-fold (0.33 log units) above it, within the range that was stated.
By their numbers in this assay, from the lowest: compounds 1, 4 and 3 (each within the scatter of the next); then compound 2.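

In this assay, going by these compounds alone, the alkyl on the oxygen is altered directly for the first time: cyclohexyl in place of isobutyl gives a 1.1-fold lower number from compound 3 to compound 4 (0.06 log units; within the scatter) and so leaves the number within the scatter, with a six-membered non-aromatic ring serving there as well as the open isobutyl. Cyclohexyloxy in place of 4-ethylpiperidin-1-yl gives no change at the digits printed from compound 1 to compound 4 (within the scatter) at the same aromatic carbon, whereas a 20-fold lower number from compound 2 to compound 4 (1.29 log units; beyond the scatter) shows that a cyclohexyl does not in itself bring the large step, since compound 2 and compound 4 both carry one. No evidence is available to explain these results.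

The compounds shown leave open how far the alkyl on that oxygen can grow before the number moves. They also do not show whether a phenyl or a chain ending in a carboxylic acid would be tolerated there.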